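Shifting the fluoro group on the fluorophenyl

This account rests on a few compounds, and the source may have more. Where it says the series, first, only, none or still open, it means among the compounds named here.

In a functional assay on HL-60 cells (Homo sapiens) for antiproliferative activity, read by sulforhodamine B assay, with a stated time of 72 h (on this read-out lower numbers stand for stronger inhibition and higher numbers for weaker inhibition), compound 1 (`N#Cc1ccc(NC(=S)N/N=C/c2ccc3ccccc3n2)cc1`) gives 4660 nM and compound 2 (`Fc1ccc(NC(=S)N/N=C/c2ccc3ccccc3n2)cc1`) gives 17000 nM as the higher of the two numbers, so compound 2 is the weaker inhibitor of the pair. Compound 3 (`Fc1cccc(NC(=S)N/N=C/c2ccc3ccccc3n2)c1`) carries 3-fluorophenyl in place of 4-fluorophenyl on an amide-type nitrogen. Among the compounds with values here, only one measured step is available (a 3.6-fold higher number from compound 1 to compound 2 (0.56 log units; beyond the scatter)). It is modest and beyond the scatter, but it exchanges one group for another, with fluoro in place of cyano, so it bears only loosely on a change of fluoro position. Within the data shown here, no measured step shows such a change, and the direction stays open. The expected change is therefore small and within the scatter (a 1.2-fold lower number from compound 2 to compound 3 (0.08 log units; within the scatter)). For compound 3 the estimated value is 14000 nM, with an expected range from 6000 nM to 35000 nM.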

Compound 3, half-maximal inhibitory concentration: 43800 nM
For compound 3 the middle estimate is 3.1-fold (0.50 log units) below the measured one; measured number outside the range, above it.
By their numbers in this assay, from the lowest: compound 1; then compound 2; then compound 3.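

Changing only the place of the fluoro group shifts the read-out in this assay, with a 2.6-fold higher number from compound 2 to compound 3 (0.41 log units; beyond the scatter) as the step, so 3-fluorophenyl and 4-fluorophenyl on the amide-type nitrogen are not interchangeable in this pair. The step of a 9.4-fold higher number from compound 1 to compound 3 (0.97 log units; beyond the scatter) is larger, and compound 1, with 4-cyanophenyl, now has the lowest number of the three, with its steps to both fluorophenyl compounds beyond the scatter. Nothing available explains why the fluoro position matters.

On these data alone, it remains open whether the gap between these two fluorophenyl groups is specific to fluoro or also appears with chloro or methoxy. Also open, as far as these compounds go, is how an amine or a carboxylic acid on the phenyl ring would compare with 4-cyanophenyl.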